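The source may hold more compounds than are shown below. What is called first, only, known or untested is meant among the compounds shown, and "the series" means these compounds.

Working notes on the series. In an assay on NIH3T3 cells with Urotensin-2 receptor (Homo sapiens) as the target (a higher number here means that more compound is needed for the effect, a lower number that less compound is needed), compound 1 `COc1ccc(C(=O)NC(CCN(C)C)c2ccc(Cl)cc2)cc1` gives 1350 nM. Compound 2 `Cc1ccc(C(=O)NC(CCN(C)C)c2ccc(Cl)cc2)c(C)c1` gives 1550 nM in this assay, and the step of a 1.1-fold higher number from compound 1 to compound 2 (0.06 log units; within the scatter) stays within the scatter. Compound 3 `Cc1cccc(Cl)c1C(=O)NC(CCN(C)C)c1ccc(Cl)cc1` gives 5130 nM in this assay, the highest number of the three; the steps of a 3.8-fold higher number from compound 1 to compound 3 (0.58 log units; beyond the scatter) and a 3.3-fold higher number from compound 2 to compound 3 (0.52 log units; beyond the scatter) are both modest and beyond the scatter, so compound 3 sits at the weak end of what has been measured. Compound 4 `Cc1ccccc1NC(=O)NC(CCN(C)C)c1ccc(Cl)cc1` is not yet measured. The change is (2-methylphenyl)amino in place of 2-chloro-6-methylphenyl on a carbonyl carbon. Within the data shown here, no measured step covers an amino group on the carbonyl carbon; the known steps concern only aryl exchanges at that position. The expected step is a 2.1-fold lower number from compound 3 to compound 4 (0.31 log units; beyond the scatter), a loose guess leaning back toward the middle of the measured range. Compound 4 is estimated at 2500 nM in this assay, with a range of 800 nM to 8000 nM.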

Compound 4, half-maximal effective concentration: 2290 nM
For compound 4 the middle estimate is 1.1-fold (0.04 log units) above the measured one; low and high end bracket the measured number.
By their numbers in this assay, from the lowest: compounds 1, 2 and 4 (each within the scatter of the next); then compound 3.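

In this assay, the carbonyl carbon accepts (2-methylphenyl)amino, which carries a hydrogen-bond donor, in place of an aryl group: the change gives a 2.2-fold lower number from compound 3 to compound 4 (0.35 log units; beyond the scatter), while a 1.5-fold higher number from compound 2 to compound 4 (0.17 log units; within the scatter) and a 1.7-fold higher number from compound 1 to compound 4 (0.23 log units; within the scatter) both stay within the scatter. An amino link at this position therefore keeps compound 4 level with compound 1 and compound 2, leaving compound 3 apart from the other three. Nothing available explains this result.

Whether the amide hydrogen matters remains open, since a methylated amino nitrogen is not among these compounds. Also open, on these data alone, is how a benzylamino group or an ether oxygen in that link would compare.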